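The compounds below may be only part of what the source reports. "The series", "measured", "known", "first", "only" and "open" are said of these compounds alone.

Of the compounds shown here, two have been measured in a functional assay on HepG2 cells (Homo sapiens) for inhibition, read by MTT assay, with a stated time of 24 h, tested at 10 uM; a higher number here means more inhibition of growth at the concentration tested, a lower number less inhibition of growth. Compound 1 `CS(=O)(=O)c1ccc(-c2cnc3[nH]cc(-c4nnc(-c5ccncc5)o4)c(=O)c3c2)cc1` gives 6.65% in this assay. Compound 2 `CS(=O)(=O)c1ccc(-c2cnc3[nH]cc(-c4nnc(-c5ccc(F)cc5)o4)c(=O)c3c2)cc1` gives 11.1% in this assay. Compound 2 holds the larger of these two numbers, but the step of a number 4.5 percentage points higher from compound 1 to compound 2 (within the scatter) lies within the usual scatter, so the two compounds cannot be separated on what has been seen so far.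

The next compound, compound 3 `CS(=O)(=O)c1ccc(-c2cnc3[nH]cc(-c4nnc(-c5ccccc5)o4)c(=O)c3c2)cc1`, has not yet been measured. It differs from compound 2 in one place: hydrogen in place of fluoro on an aromatic carbon, on an aromatic carbon of a six-membered aromatic ring of carbon only; read one bond further out, this is 4-fluorophenyl giving way to phenyl. Among the measured compounds shown here, no measured step removes a fluoro in this way. For the measured compounds named here, the only step available, a number 4.5 percentage points higher from compound 1 to compound 2 (within the scatter), swapped one aromatic group for a different one and still stayed within the scatter. There is therefore no ground to expect a change beyond the scatter, and the step from compound 2 to compound 3 is estimated as a number 2.1 percentage points lower from compound 2 to compound 3 (within the scatter). Compound 3 is expected to give 9% in this assay, with a range from 0% to 20%.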

Compound 3, percent growth inhibition at one concentration: 6.98%
Beside the measured number, compound 3's estimate is 2 percentage points above it; the range from low to high includes it.
By their numbers in this assay, from the lowest: compounds 1, 3 and 2 (each within the scatter of the next).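

In this assay, taking away the fluoro that sat para to a large group on a six-membered aromatic ring of carbon only gives a number 4.1 percentage points lower from compound 2 to compound 3 (within the scatter), so at this position fluoro and hydrogen cannot be told apart. Replacing the pyridin-4-yl with phenyl gives a number 0.3 percentage points higher from compound 1 to compound 3 (within the scatter), which adds a second comparison at the same place on the molecule. Pyridin-4-yl, phenyl and 4-fluorophenyl now all lie within the scatter of one another, and nothing measured alongside these numbers explains why they sit so close together.

The compounds shown leave open whether a group of a different kind on that ring, such as an amine, a carboxylic acid or a longer chain in place of the fluoro, would shift the number beyond the scatter. They also leave open whether a change to the shared core, rather than to this aromatic group, would do so.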